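Replacing 3-Fluorophenyl with (Morpholin-4-yl)carbonyl: Cytotoxicity Outlook

A few compounds are considered here, and "the series" means these few. Any claim that something is new, unique, unknown or untested is made for them only; others in the source may bear on it.

Measured in an ADME assay on MT4 cells (Homo sapiens) for cytotoxicity, read by MTT assay, with a stated time of 5 days; on this read-out higher numbers stand for lower toxicity in this test and lower numbers for higher toxicity in this test:

compound 1 `Cc1cc(C)c(Oc2cc(Nc3ccc(C#N)cc3)ncc2C(=O)NCc2cn(Cc3ccccc3[N+](=O)[O-])nn2)c(C)c1` gives > 212000 nM
compound 2 `Cc1cc(C)c(Oc2cc(Nc3ccc(C#N)cc3)ncc2C(=O)NCc2cn(Cc3cccc(Cl)c3)nn2)c(C)c1` gives 187000 nM
compound 3 `Cc1cc(C)c(Oc2cc(Nc3ccc(C#N)cc3)ncc2C(=O)NCc2cn(Cc3cccc(F)c3)nn2)c(C)c1` gives >= 204000 nM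

The value of compound 3 is a limit of the assay, not a number. The value of compound 1 is likewise a limit. Compound 2 alone gives a plain number, and the step of an at least 1.0-fold higher number from compound 2 to compound 3 (0.03 log units; that floor lies within the scatter) shows that compound 3 is no more toxic than compound 2 as far as the limit allows. The step of an at least 1.1-fold lower number from compound 1 to compound 2 (0.05 log units; that floor lies within the scatter) is small, and the step that the two limits leave unreadable from compound 1 to compound 3 cannot be read because both ends are limits. All three compounds therefore sit at or near the top of what this test can report.

Compound 4 `Cc1cc(C)c(Oc2cc(Nc3ccc(C#N)cc3)ncc2C(=O)NCc2cn(CC(=O)N3CCOCC3)nn2)c(C)c1` differs from compound 3 by (morpholin-4-yl)carbonyl in place of 3-fluorophenyl on a saturated chain carbon bound to an aromatic nitrogen. Going by the values given here, none of the measured steps exchanges an aromatic group for an amide-bearing chain, so no step speaks directly to this change; the measured steps only show that changes on this chain carbon have so far stayed within the scatter. In this assay the step of an at least 1.0-fold lower number from compound 3 to compound 4 (0.00 log units; that floor lies within the scatter) is therefore expected to stay within the scatter. For compound 4 the value expected is 200000 nM, with a range from 100000 nM to 300000 nM, and a limit rather than a number is the likelier outcome.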

Compound 4, half-maximal cytotoxic concentration: 181000 nM
Compound 4: the middle estimate sits 1.1-fold (0.04 log units) above what was measured; the range from low to high includes it.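

Compound 4 is the first compound shown whose group on the saturated chain carbon bound to an aromatic nitrogen holds no aromatic ring, yet this assay gives a 1.0-fold lower number from compound 2 to compound 4 (0.01 log units; within the scatter), the only new step between two plain numbers. Thus a non-aromatic ring with 2 hydrogen-bond acceptors, (morpholin-4-yl)carbonyl, can stand in for 3-chlorophenyl at this position with no readable change in this test. The other two steps, an at least 1.1-fold lower number from compound 3 to compound 4 (0.05 log units; that floor lies within the scatter) and an at least 1.1-fold lower number from compound 1 to compound 4 (0.06 log units; that floor lies within the scatter), start from limits of the assay, so they give only floors and no full size.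

The compounds shown leave open whether an amine, a carboxylic acid or a longer chain at this position would also leave the number unmoved. Also open, going by these compounds, is what plain numbers compound 1 and compound 3 would give.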